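Lactam in place of hydroxypyridine on the amide carbonyl

The source may report more compounds than this note shows. Statements on the series, on what has been measured and on what is new or still open speak of the compounds shown alone.

Of the compounds shown here, three have so far been measured in an assay on cells for positive allosteric modulation of Cystic fibrosis transmembrane conductance regulator variant F508del (Homo sapiens), with stated times of 10 min and 7 s, in the presence of a further agent that is not named here; a higher number here means that more compound is needed for the effect, a lower number that less compound is needed. Compound 1, `Cc1ccc(C(=O)Nc2sc3c(c2C(N)=O)CCCC3)s1`, gives 652 nM. Compound 2, `CC1(C)Cc2c(sc(NC(=O)c3ccccc3O)c2C(N)=O)CO1`, gives 13 nM. Compound 3, `CC1(C)Cc2c(sc(NC(=O)c3cccnc3O)c2C(N)=O)C(C)(C)O1`, gives 190 nM, which is the second highest of the three numbers: its gap to compound 1 lies beyond the usual scatter, and its gap to compound 2 lies well beyond it, with compound 2 the lower of the two.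

The unmeasured compound 4, `CC1(C)Cc2c(sc(NC(=O)C3CCNC3=O)c2C(N)=O)C(C)(C)O1`, differs from compound 3 in one place: 2-oxopyrrolidin-3-yl in place of 2-hydroxypyridin-3-yl on a carbonyl carbon. Among the compounds with values here, no pair of measured compounds shows this change, so its effect cannot be read directly from the numbers at hand; the two aromatic acyl groups of compounds 2 and 3 give the two lower values, and nothing is known about a non-aromatic group in this position. For compound 4 the step of a 3.2-fold higher number from compound 3 to compound 4 (0.50 log units; beyond the scatter) is expected to point toward a higher number, of moderate size. Compound 4 is therefore estimated at 600 nM, within a range from 150 nM to 3000 nM.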

Compound 4, half-maximal effective concentration: 101 nM
The estimate for compound 4 lay 5.9-fold (0.77 log units) above the measured number; measured number below the stated range.
By their numbers in this assay, from the lowest: compound 2; then compounds 4 and 3 (each within the scatter of the next); then compound 1.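

In this assay, 2-oxopyrrolidin-3-yl in place of 2-hydroxypyridin-3-yl on a carbonyl carbon gives a 1.9-fold lower number from compound 3 to compound 4 (0.27 log units; within the scatter), so the two groups cannot be told apart by this read-out. Within the data shown here, this is the first measured case of a non-aromatic ring at this position, and for this pair the six-membered aromatic ring can give way to a five-membered non-aromatic lactam ring with no change beyond the scatter. Nothing at hand accounts for this result.

On these data alone, what an open-chain amine, a carboxylic acid or a six-membered lactam would give on this carbonyl carbon remains open. As far as these compounds go, it is also open whether 2-oxopyrrolidin-3-yl would give a similar result on the core of compound 2, which has the lowest number so far.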